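Isopropyl Added to the Longer-Chain Sulfonamide Acid

The compounds below may be only part of what the source reports. "The series", "measured", "known", "first", "only" and "open" are said of these compounds alone.

Compound 1 `O=C(O)c1cc(CCCCCNS(=O)(=O)c2ccccc2)c2cccccc1-2` and compound 3 `CC(C)c1ccc2c(CCCCCNS(=O)(=O)c3ccccc3)cc(C(=O)O)c-2cc1` differ only by isopropyl in place of hydrogen on an aromatic carbon. In a functional assay (thoracic aorta) for inhibition, with Rattus norvegicus as the target (on this read-out lower numbers stand for stronger inhibition and higher numbers for weaker inhibition), compound 1 gives 840 nM and compound 3 gives 120 nM; the step is a 7.0-fold lower number from compound 1 to compound 3 (0.85 log units; beyond the scatter). Compound 2 `O=C(O)c1cc(CCCCCCCNS(=O)(=O)c2ccccc2)c2cccccc1-2` carries a longer chain; how its core and that of compound 1 differ is not broken down here. In this assay compound 2 gives 18 nM, the lowest of the three measured numbers, beyond the scatter of both others. Compound 4 `CC(C)c1ccc2c(CCCCCCCNS(=O)(=O)c3ccccc3)cc(C(=O)O)c-2cc1` is related to compound 2 by isopropyl in place of hydrogen on an aromatic carbon, the same change seen from compound 1 to compound 3. Compound 4 is expected to show a 4.5-fold lower number from compound 2 to compound 4 (0.65 log units; beyond the scatter), a step kept a little smaller than a 7.0-fold lower number from compound 1 to compound 3 (0.85 log units; beyond the scatter) since the same change is applied on a longer chain. Compound 4 is therefore estimated at 4 nM in this assay, between 1.5 nM and 15 nM.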

Compound 4, half-maximal inhibitory concentration: 120 nM
Compound 4: middle estimate off by 30-fold (1.48 log units), on the low side; measured number outside the range, above it.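

In this assay, isopropyl in place of hydrogen on an aromatic carbon gives a 6.7-fold higher number from compound 2 to compound 4 (0.82 log units; beyond the scatter), the opposite direction to the step seen on the shorter chain. The benefit seen with compound 3 therefore cannot simply be carried over to another core in this series: the same change on two cores in this assay, a 7.0-fold lower number (0.85 log units; beyond the scatter) from compound 1 to compound 3 and a 6.7-fold higher number (0.82 log units; beyond the scatter) from compound 2 to compound 4, 47-fold (1.67 log units) apart, beyond the scatter of two such steps. These two pairs do not show why the steps go opposite ways, nor how the change behaves at any other chain length.

On these data alone, it remains open whether methyl or tert-butyl on that same aromatic carbon would follow the step to compound 3 or the step to compound 4. Also open, as far as these compounds go, is what isopropyl would do with a chain longer than that of compound 1 yet shorter than that of compound 2.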